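Removing one ester group from compound 3

The compounds below may be only part of what the source reports. "The series", "measured", "known", "first", "only" and "open" are said of these compounds alone.

In a functional assay on PC-3 cells (Homo sapiens) for antiproliferative activity, read by MTT assay, with a stated time of 72 h (on this read-out lower numbers stand for stronger inhibition and higher numbers for weaker inhibition), compound 1 `COc1cc(/C=C/C(=O)/C=C(O)/C=C/c2ccc(OC(=O)C(C)(CO)CO)c(OC)c2)ccc1OC(=O)C(C)(CO)CO` gives 3900 nM while compound 2 `CCC(CO)(CO)C(=O)Oc1ccc(/C=C/C(=O)/C=C(O)/C=C/c2ccc(OC(=O)C(CC)(CO)CO)c(OC)c2)cc1OC` gives 4210 nM and compound 3 `CC(CO)(CO)C(=O)Oc1ccc(/C=C/C(=O)/C=C(O)/C=C/c2ccc(OC(=O)C(C)(CO)CO)cc2)cc1` gives 5590 nM on the same test. These three values lie within the usual scatter of one another, so compound 3 stands level with the other two. Compound 4 `CC(CO)(CO)C(=O)Oc1ccc(/C=C/C(=O)/C=C(O)/C=C/c2ccc(O)cc2)cc1` differs from compound 3 by one change hydrogen in place of (1,1-bis(hydroxymethyl)ethyl)carbonyl on an oxygen on an aromatic ring in which hydrogen stands in place of (1,1-bis(hydroxymethyl)ethyl)carbonyl on an oxygen on an aromatic ring. Among the measured compounds shown here, no measured pair shows this change, so the expectation rests only on that narrow spread of values. The estimated step of a 1.2-fold higher number from compound 3 to compound 4 (0.07 log units; within the scatter) is small, points to a slightly higher number in this assay and is not expected to exceed the scatter. For compound 4 the expected value is 6500 nM with an estimated range from 2800 nM to 15000 nM on this test.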

Compound 4, half-maximal inhibitory concentration: 5220 nM
For compound 4 the middle estimate is 1.2-fold (0.10 log units) above the measured one; the range from low to high includes it.
By their numbers in this assay, from the lowest: compounds 1, 2, 4 and 3 (each within the scatter of the next).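

In this assay, among the compounds shown here, hydrogen in place of (1,1-bis(hydroxymethyl)ethyl)carbonyl on an oxygen on an aromatic ring gives a 1.1-fold lower number from compound 3 to compound 4 (0.03 log units; within the scatter) as the first measured step at this place. Compound 4, with a hydroxy on that oxygen, thus stands level with compound 3, so one of the two ester groups can go without a step beyond the scatter. No evidence here explains this result.

As far as these compounds go, whether the remaining ester group can also go stays open. So does how an acetyl group or a longer alkyl chain on this oxygen would compare.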